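Swapping the amine arm on compound 2: what to expect

A few compounds are considered here, and "the series" means these few. Any claim that something is new, unique, unknown or untested is made for them only; others in the source may bear on it.

Measured so far:
- compound 1, `CCN(Cc1ccccc1)Cc1ccc(CN2CCc3ccc(OS(N)(=O)=O)cc3C2)cc1`: 1%
- compound 2, `CCN(Cc1ccncc1)c1ccc(C(=O)N2CCc3ccc(OS(N)(=O)=O)cc3C2)cc1`: 47%
- compound 3, `CCN(Cc1ccccc1)Cc1ccc(S(=O)(=O)N2CCc3ccc(OS(N)(=O)=O)cc3C2)cc1`: 10%

All three were tested in an assay on HEK293 cells for inhibition of Steryl-sulfatase (Homo sapiens), tested at 0.1 uM; on this read-out higher numbers stand for a stronger effect at the one concentration tested and lower numbers for a weaker effect. Among the three numbers, compound 2 stands highest: the nearest of the other two is compound 3, and its number lies beyond the scatter below compound 2; compound 1 lies further still below. Within the data shown here, compound 2 is therefore the one compound of this set with a clearly stronger effect at the concentration tested.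

The next compound, compound 4, has the structure `CN(CCCN1CCCCC1)c1ccc(C(=O)N2CCc3ccc(OS(N)(=O)=O)cc3C2)cc1`. It differs from compound 2 in one place only: methyl(3-(piperidin-1-yl)propyl)amino in place of ethyl((pyridin-4-yl)methyl)amino on an aromatic carbon. Everything else in the molecule is kept as it is in compound 2.

Among the measured compounds shown here, no pair of measured compounds differs in just one place, so there is no measured step of this kind to lean on. The change exchanges one amine arm for another of similar size, and with no such comparison at hand the expectation is a modest move, more likely downward than upward, with a step of a number 12 percentage points lower from compound 2 to compound 4 (beyond the scatter) in this assay that could also turn out to be none beyond the scatter. Compound 4 is thus estimated at 35%, within a range from 10% to 65%.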

Compound 4, a percentage reported as inhibition, at one concentration (the size of the read-out at that concentration, not a potency): 17.4%
The estimate for compound 4 lay 17.6 percentage points above the measured number; the measured number falls inside the stated range.
By their numbers in this assay, from the lowest: compounds 1, 3 and 4 (each within the scatter of the next, the first and the last beyond it); then compound 2.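

In this assay, placing methyl(3-(piperidin-1-yl)propyl)amino where ethyl((pyridin-4-yl)methyl)amino stood gives a number 29.6 percentage points lower from compound 2 to compound 4 (beyond the scatter), the only step shown between two compounds that differ in one place, and it shows that the read-out responds to the choice of amine arm on this aromatic carbon, para to a large group. The two arms have the same counts of hydrogen-bond donors and acceptors, neither carries a net charge, and their heavy-atom counts are close. The clearest printed difference is a six-membered aromatic ring with one hetero atom giving way to a six-membered non-aromatic ring with one hetero atom. Nothing available here explains the drop.

Going by these compounds, the swap alters the ring, the chain joining it to the nitrogen and the small alkyl group on that nitrogen all at once, so the part responsible for the step remains open. A morpholine ring on the same propyl chain, or a shorter ethyl chain carrying the piperidine ring, would begin to separate these parts.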